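Diaryl ether in place of an alkyl chain: permeability outlook

The compounds below may be only part of what the source reports. "The series", "measured", "known", "first", "only" and "open" are said of these compounds alone.

The measured compounds are compound 1 `COc1cccc(CNCCCNc2ccnc3cc(CCC(C)C)ccc23)c1O`, compound 2 `CCC(CC)c1ccc2c(NCCCNCc3cccc(OC)c3O)ccnc2c1` and compound 3 `CC(C)(C)c1ccc(Oc2ccc3c(NCCCNCc4ccco4)ccnc3c2)cc1`. In an ADME assay for permeability, using PAMPA, with a stated time of 30 min, at pH 7.4 (on this read-out lower numbers stand for lower permeability and higher numbers for higher permeability), compound 1 gives 23 10^-6 cm/s, compound 2 gives 23 10^-6 cm/s and compound 3 gives 317 10^-6 cm/s.

Compound 2 stands level with compound 1 and together they give the lowest numbers of the three; compound 3 gives a far higher number, well beyond the scatter. Within the data shown here, the only single-place step measured, no change at the digits printed from compound 1 to compound 2 (within the scatter), shows that swapping one alkyl group for another leaves the read-out untouched. Among the measured compounds shown here, compound 3 differs from compound 2 in more than one place, so no measured step isolates its higher number.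

Compound 4 `COc1cccc(CNCCCNc2ccnc3cc(Oc4cccc(N(C)C)c4)ccc23)c1O` is not yet measured. It differs from compound 2 by 3-(dimethylamino)phenoxy in place of pentan-3-yl on an aromatic carbon. This brings in an aryl ether of the kind found in compound 3, while the rest of compound 2 is kept. Since compound 3 gives 317 10^-6 cm/s and compound 2 gives 23 10^-6 cm/s, some rise is expected, but the other differences between those two compounds are unaccounted for, so the rise expected for a 2.0-fold higher number from compound 2 to compound 4 (0.29 log units; within the scatter) is held to a moderate size. Compound 4 is therefore estimated at 45 10^-6 cm/s, with a range of 15 10^-6 cm/s to 150 10^-6 cm/s.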

Compound 4, apparent permeability: 317 10^-6 cm/s
Compound 4: the middle estimate sits 7.0-fold (0.85 log units) below what was measured; the whole stated range lies below it.
By their numbers in this assay, from the lowest: compounds 1 and 2 (each within the scatter of the next); then compounds 3 and 4 (each within the scatter of the next).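

In this assay, the position on the aromatic carbon, meta to a fused ring and para to a fused ring, proved far from indifferent to what it carries, although the exchange of one alkyl group for another had suggested otherwise, with no change at the digits printed from compound 1 to compound 2 (within the scatter). Placing 3-(dimethylamino)phenoxy there in place of pentan-3-yl gave a 14-fold higher number from compound 2 to compound 4 (1.14 log units; beyond the scatter), and the same group in place of isopentyl gave a 14-fold higher number from compound 1 to compound 4 (1.14 log units; beyond the scatter), so this single change, with the rest of the structure held constant, is enough to move the read-out well beyond the scatter. Nothing on hand explains the size of this step.

What the compounds shown leave open is which part of the entering group goes with the higher number, the ether oxygen, the aromatic ring or the dimethylamino group, and an unsubstituted phenoxy or a cyclohexyloxy at the same place would bear on that question. Going by these compounds, whether a primary amine or a methoxy in place of the dimethylamino group would hold the number at this level also remains open.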